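The source may hold more compounds than are shown below. What is called first, only, known or untested is meant among the compounds shown, and "the series" means these compounds.

Compound 1 `COc1ccc(OC)c(C2=C(c3cc(OC)c(OC)c(OC)c3)C(=O)CC2O[SiH2]C(C)(C)C)c1` is the only one of the three measured compounds that gives a number in an ADME assay on KB cells (Homo sapiens) for cytotoxicity, read by MTT assay, with a stated time of 72 h; a higher number here means a weaker inhibitor, a lower number a stronger inhibitor: compound 1 gives 10 ug/mL. Compound 2 `COc1ccc(C2=C(c3cc(OC)c(OC)c(OC)c3)CC(O)C2=O)cc1[N+](=O)[O-]` reaches only a limit of the assay in this assay, where compound 2 gives > 100 ug/mL. Compound 3 `COc1ccc(C2=C(c3cc(OC)c(OC)c(OC)c3)CC(O[SiH2]C(C)(C)C)C2=O)cc1[N+](=O)[O-]` likewise stops at a limit in this assay, where compound 3 gives > 100 ug/mL. Between compound 3 and compound 2 the change is a hydrogen atom in place of a group of 5 heavy atoms (4 carbon, 1 silicon; no ring), on an oxygen on a saturated carbon, and the step that the two limits leave unreadable from compound 3 to compound 2 cannot be read, because both values sit at the limit of > 100 ug/mL in this assay, at which 2 of the 3 values shown sit.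

Compound 4 `COc1ccc(OC)c(C2=C(c3cc(OC)c(OC)c(OC)c3)C(=O)CC2O)c1` has not been tested. It differs from compound 1 by a hydrogen atom in place of a group of 5 heavy atoms (4 carbon, 1 silicon; no ring), on an oxygen on a saturated carbon, the same change as from compound 3 to compound 2, at the same place. The difference between the core of compound 1 and the core of compound 3 is not broken down here.

The one earlier occurrence of this change gives no readable size, so the expectation for compound 4 rests mainly on compound 1 with its value of 10 ug/mL, and the step is estimated as a 2.0-fold higher number from compound 1 to compound 4 (0.30 log units; within the scatter), within the usual scatter. Compound 4 is thus expected to give about 20 ug/mL in this assay, estimated to lie between 4 ug/mL and 100 ug/mL.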

Compound 4, half-maximal inhibitory concentration: > 100 ug/mL
Compound 4: no number, only a limit (the forecaster's own chance of this, stated with the estimate: 25%); middle value at least 5.0-fold (0.69 log units) away from the limit.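

In this assay, putting a hydrogen atom in place of the group of 5 heavy atoms (4 carbon, 1 silicon), on an oxygen on a saturated carbon, gives an at least 10-fold higher number from compound 1 to compound 4 (1.00 log units; beyond the scatter), so on this core the group cannot be removed without a clear loss in the read-out. Compound 4 gives > 100 ug/mL, which is a limit of the assay and not a number. The same change on the other core, from compound 3 to compound 2, cannot be read, so nothing here shows that the change carries over from one core to the other, and compound 3 shows that the group alone does not bring a number, because both ends of that step rest on the same limit: the limit of > 100 ug/mL in this assay, at which 3 of the 4 values shown sit.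

The compounds shown hold only two ends of the change, the hydrogen atom and the group of 5 heavy atoms, so it stays open how a methyl ether, an acetyl ester or a longer carbon chain on that oxygen would read in this assay. Going by these compounds, it also stays open whether any such group on the core of compound 3 would give a number at all.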